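Swapping the aryl group on the amide carbonyl

This account rests on a few compounds, and the source may have more. Where it says the series, first, only, none or still open, it means among the compounds named here.

Of the compounds shown here, three share a core and have been measured in an assay on MDA-MB-231 cells for binding affinity to C-X-C chemokine receptor type 4 (Homo sapiens), read by immunofluorescence and microscopy, with stated times of 10 min and 30 min; on this read-out lower numbers stand for an effect already at smaller amounts and higher numbers for an effect only at larger amounts of compound. Compound 1 `O=C(NCc1ccc(CNS(=O)(=O)c2ccccc2)cc1)c1cccc(F)c1` gives 100 nM, compound 3 `O=C(NCc1ccc(CNS(=O)(=O)c2ccccc2)cc1)c1cccnc1` gives 10 nM, and compound 2 `COc1cccc(C(=O)NCc2ccc(CNS(=O)(=O)c3ccc(C)cc3)cc2)c1` gives 10 nM. Compound 2 thus sits level with compound 3 at the digits shown, the two together at the low end of the set, while compound 1 stands a full step higher. Compound 4 `Cc1ccc(S(=O)(=O)NCc2ccc(CNC(=O)c3ccccc3Cl)cc2)cc1` is not yet measured; it differs from compound 2 only at the carbonyl carbon: 2-chlorophenyl in place of 3-methoxyphenyl on a carbonyl carbon.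

Among the measured compounds shown here, one measured step touches this same position: a 10-fold lower number from compound 1 to compound 3 (1.00 log units; beyond the scatter). For the measured compounds named here, it shows that exchanging the aryl group on the carbonyl carbon can shift the result well beyond the scatter, but no measured pair tells how a 2-chlorophenyl behaves there. Compound 1, which like compound 4 carries a halogen on this ring, gave the highest number of the three, so the change is expected to cost somewhat: a 3.0-fold higher number from compound 2 to compound 4 (0.48 log units; beyond the scatter). Compound 4 is therefore estimated at 30 nM, with a range from 5 nM to 200 nM.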

Compound 4, effective concentration (reported as EC, without a stated level of effect): 10 nM
Compound 4: middle estimate off by 3.0-fold (0.48 log units), on the high side; the measured number falls inside the stated range.
By their numbers in this assay, from the lowest: compounds 2, 3 and 4 (each within the scatter of the next); then compound 1.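

Replacing 3-methoxyphenyl with 2-chlorophenyl on the carbonyl carbon gives no change at the digits printed from compound 2 to compound 4 (within the scatter) in this assay. The earlier step at this position, a 10-fold lower number from compound 1 to compound 3 (1.00 log units; beyond the scatter), showed that the aryl group here can move the number, whereas this pair shows that two differently substituted phenyl rings can also read alike. In this pair, the hydrogen-bond acceptor counted on 3-methoxyphenyl can go, and a chlorine can enter, with no shift beyond the scatter. No available evidence accounts for this result.

Still open, going by these compounds, is whether the same holds for the isomeric pair, with 2-methoxyphenyl and 3-chlorophenyl on this carbonyl carbon. On these data alone, it is equally open whether a non-aromatic group in place of the ring, such as a cyclohexyl ring or a longer alkyl chain carrying an amine, would keep the number level.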